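The Same Isopropyl-to-Iodo Swap, Made Twice

The source may hold more compounds than are shown below. What is called first, only, known or untested is meant among the compounds shown, and "the series" means these compounds.

Compound 1 `CC(C)c1ccccc1OS(=O)(=O)c1ccc(NC(=O)CCCCl)cc1` gives 6200 nM in a functional assay on HT-29 cells (Homo sapiens) for antiproliferative activity, read by sulforhodamine B assay, with a stated time of 48 h; a higher number here means a weaker inhibitor, a lower number a stronger inhibitor. Compound 2 `O=C(CCCCl)Nc1ccc(S(=O)(=O)Oc2ccccc2I)cc1` differs from it by iodo in place of isopropyl on an aromatic carbon and gives 9100 nM in this assay, a step of a 1.5-fold higher number from compound 1 to compound 2 (0.17 log units; within the scatter). Compound 3 `CCCCCNC(=O)Nc1ccc(S(=O)(=O)Oc2ccccc2C(C)C)cc1` differs from compound 1 by pentylamino in place of 3-chloropropyl on a carbonyl carbon. In this assay compound 3 gives 4900 nM, a step of a 1.3-fold lower number from compound 1 to compound 3 (0.10 log units; within the scatter). Compound 4 `CCCCCNC(=O)Nc1ccc(S(=O)(=O)Oc2ccccc2I)cc1` has not yet been measured; it differs from compound 3 by iodo in place of isopropyl on an aromatic carbon, the same change that turned compound 1 into compound 2, at a place described in identical words. Because that change earlier gave a 1.5-fold higher number from compound 1 to compound 2 (0.17 log units; within the scatter), compound 4 is expected to show a step of about a 1.5-fold higher number from compound 3 to compound 4 (0.17 log units; within the scatter). The estimated value of compound 4 in this assay is 7200 nM, expected to lie between 3500 nM and 15000 nM.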

Compound 4, half-maximal inhibitory concentration: 6600 nM
Compound 4: middle estimate off by 1.1-fold (0.04 log units), on the high side; measured number inside the range.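

In this assay, iodo in place of isopropyl gave a 1.3-fold higher number from compound 3 to compound 4 (0.13 log units; within the scatter), and this step matches the one on the other core: the same change on two cores in this assay, a 1.5-fold higher number (0.17 log units; within the scatter) from compound 1 to compound 2 and a 1.3-fold higher number (0.13 log units; within the scatter) from compound 3 to compound 4, 1.1-fold (0.04 log units) apart, within the scatter of two such steps. Pentylamino in place of 3-chloropropyl gave a 1.4-fold lower number from compound 2 to compound 4 (0.14 log units; within the scatter), and this change also reads alike on both cores: the same change on two cores in this assay, a 1.3-fold lower number (0.10 log units; within the scatter) from compound 1 to compound 3 and a 1.4-fold lower number (0.14 log units; within the scatter) from compound 2 to compound 4, 1.1-fold (0.04 log units) apart, within the scatter of two such steps. Among the compounds shown here, every one of these steps lies within the scatter, so the agreement shows only that neither change detectably moved the number on these two cores, not that either has a real effect of fixed size.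

The compounds shown leave open whether a methoxy group or a carboxylic acid on that aromatic carbon would shift the number beyond the scatter. The same question remains for an amine or a longer chain on the carbonyl carbon.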